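Aryl exchange on the sulfonyl sulfur, compound 2 to compound 4

The compounds below may be only part of what the source reports. "The series", "measured", "known", "first", "only" and "open" are said of these compounds alone.

Compound 1 `Cc1ccc(S(=O)(=O)c2cnc3ccc(Cl)cc3c2N2CCC(C)CC2)cc1C`, compound 2 `Cc1ccc(S(=O)(=O)c2cnc3ccc(F)cc3c2N2CCC(C)CC2)cc1C` and compound 3 `Cc1ccc2ncc(S(=O)(=O)c3ccc(C)c(C)c3)c(N3CCC(C)CC3)c2c1` share one core and differ only in the substituent on one aromatic carbon of that core. In an assay on isolated protein for displacement of a labelled ligand from metabotropic glutamate receptor 5 (Homo sapiens), with a stated time of 60 min, tested at 1 uM (on this read-out lower numbers stand for less inhibition and higher numbers for more inhibition at the one concentration tested (going by the name of the read-out)), compound 1 gives 84%, compound 2 gives 92% and compound 3 gives 90%. Compound 2 stands highest of the three numbers shown, but the step of a number 8 percentage points higher from compound 1 to compound 2 (within the scatter), the step of a number 6 percentage points higher from compound 1 to compound 3 (within the scatter) and the step of a number 2 percentage points lower from compound 2 to compound 3 (within the scatter) all sit within the scatter, so the three compounds are not separated by these data.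

Compound 4 `CC1CCN(c2c(S(=O)(=O)c3ccc(Cl)cc3)cnc3ccc(F)cc23)CC1` keeps the core of compound 2 and changes the other side of the molecule: 4-chlorophenyl in place of 3,4-dimethylphenyl on a sulfonyl sulfur. For the measured compounds named here, none of the measured steps touches the group on the sulfonyl sulfur; each of them exchanges a substituent on an aromatic carbon of the core, and each is within the scatter. There is therefore no measured guide for this change, and the expectation rests only on the high inhibition shared by the three measured compounds. A step of a number 12 percentage points lower from compound 2 to compound 4 (beyond the scatter) is expected, leaving room for a drop beyond the scatter without a loss of most of the inhibition. Compound 4 is estimated at 80% in this assay, with a range of 55% to 95%.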

Compound 4, a percentage reported as inhibition, at one concentration (the size of the read-out at that concentration, not a potency): 80%
For compound 4 middle estimate and measured number coincide at the digits printed; the range from low to high includes it.
By their numbers in this assay, from the lowest: compounds 4, 1, 3 and 2 (each within the scatter of the next, the first and the last beyond it).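

The group on the sulfonyl sulfur is the one place in this series where a single exchange moves the read-out beyond the scatter: in this assay, the step is a number 12 percentage points lower from compound 2 to compound 4 (beyond the scatter), the only step shown of that kind, while the exchanges on an aromatic carbon of the core left compounds 1, 2 and 3 unseparated. The step is modest, and compound 4 still gives 80%, so at the one concentration tested, 4-chlorophenyl in place of 3,4-dimethylphenyl keeps substantial inhibition, although this number is not a potency. Nothing available explains why this exchange lowers the number.

Since one aryl group replaces another whole, this single step cannot show which part of the change matters, and an unsubstituted phenyl or a pyridine ring on the sulfonyl sulfur would test how far the read-out depends on the aryl group. On these data alone, it also remains open whether the step carries over to the chloro and methyl members, as 4-chlorophenyl appears here only on the core of compound 2.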